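Saturating the Bicyclic Group: From Compound 3 to Compound 4

The source may hold more compounds than are shown below. What is called first, only, known or untested is meant among the compounds shown, and "the series" means these compounds.

Three compounds built on one shared core were tested in a functional assay on the whole organism (blood) with Rattus norvegicus as the target, with stated times of 24 h and 1 h, at a dose of 5 mg/kg by the intraperitoneal route; on this read-out higher numbers stand for a stronger effect at the one dose given and lower numbers for a weaker effect. Compound 1 `COc1ccc2nccc(C(=O)NCCC3CCN(S(=O)(=O)NC(=O)NC[C@@H]4C[C@@H]5C=C[C@@H]4C5)CC3)c2c1` gives 10%. Compound 2 `COc1ncccc1C(=O)NCCC1CCN(S(=O)(=O)NC(=O)NC[C@@H]2C[C@@H]3CC[C@@H]2C3)CC1` gives 35%. Compound 3 `Cn1cc(C(=O)NCCC2CCN(S(=O)(=O)NC(=O)NC[C@@H]3C[C@@H]4C=C[C@@H]3C4)CC2)c(=O)n(C)c1=O` gives 23%, the second highest of the three numbers: compound 2 lies above it and compound 1 below it, both gaps beyond the usual scatter. Within the data shown here, the only single-point step measured so far, a number 13 percentage points higher from compound 1 to compound 3 (beyond the scatter), concerns the group on the carbonyl carbon, not the part changed here.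

Compound 4 `Cn1cc(C(=O)NCCC2CCN(S(=O)(=O)NC(=O)NC[C@@H]3C[C@@H]4CC[C@@H]3C4)CC2)c(=O)n(C)c1=O` differs from compound 3 in one place: a group of 7 heavy atoms (7 carbon; 2 five-membered non-aromatic rings of carbon only) in place of a group of 7 heavy atoms (7 carbon; 2 five-membered non-aromatic rings of carbon only), on a saturated chain carbon bound to an amide-type nitrogen. Among the measured compounds shown here, no measured step isolates this change. For the measured compounds named here, compound 1 and compound 2 differ in the same place but also on the carbonyl carbon, so their two values show only that compound 2 gives 35% while compound 1 gives 10%, which cannot be credited to the bicyclic change alone. A step of a number 5 percentage points higher from compound 3 to compound 4 (within the scatter) is therefore expected, most likely within the scatter. The estimate for compound 4 is 28%, with a range from 12% to 45%.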

Compound 4, a percentage reported as activity, at one dose (the size of the read-out at that dose, not a potency): 22%
Compound 4: the middle estimate sits 6 percentage points above what was measured; the measured number falls inside the stated range.
By their numbers in this assay, from the lowest: compound 1; then compounds 4 and 3 (each within the scatter of the next); then compound 2.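

In this assay, among these compounds, the step of a number 1 percentage points lower from compound 3 to compound 4 (within the scatter) gives the first direct reading at this position: with the double bond outside aromatic rings gone, and the 7 carbon atoms and 2 five-membered non-aromatic rings kept, the two compounds cannot be told apart. With the saturated group held fixed, the change on a carbonyl carbon can also be read on its own, and the step of a number 13 percentage points lower from compound 2 to compound 4 (beyond the scatter) shows that the group with 2 hetero atoms in its aromatic ring goes with a weaker effect than the group with 1. No measurement shown here explains either step.

Among the compounds shown here, whether the double bond matters as little with other groups on the carbonyl carbon remains open, as only this one pair isolates it. On these data alone, the effect of a hydroxyl group on the bicyclic group, or of a simple cyclohexyl ring in its place, also remains unknown.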